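This account rests on a few compounds, and the source may have more. Where it says the series, first, only, none or still open, it means among the compounds named here.

Going by the values given here, compound 3 `Cn1c(-c2ccc(F)cc2)nc2c(NC3CCCC3)ncnc21` is one of three compounds measured in a functional assay on CHO cells for antagonist activity at adenosine receptor A2b (Homo sapiens), read by 33P incorporation, with a stated time of 20 min; on this read-out lower numbers stand for stronger inhibition and higher numbers for weaker inhibition. For compound 3 the reading is a limit of the assay, > 30000 nM. Compound 1 `Cn1c(-c2ccccc2)nc2c(NC3CCCC3)ncnc21` gives 8510 nM in this assay. Compound 2 `Cn1c(-c2cccnc2)nc2c(NC3CCCC3)ncnc21` also returns only a limit, > 30000 nM. Compound 3 therefore stands at the weak end of what is known, at the limit of > 30000 nM in this assay, at which 2 of the 3 values shown sit. Compound 4 `Cn1c(-c2ccccc2Cl)nc2c(NC3CCCC3)ncnc21` differs from compound 3 by 2-chlorophenyl in place of 4-fluorophenyl on an aromatic carbon. Among the compounds with values here, no measured step swaps one halogenated phenyl for another; the nearest comparison is an at least 3.5-fold higher number from compound 1 to compound 3 (0.54 log units; beyond the scatter), while a step that the two limits leave unreadable from compound 2 to compound 3. Both the halogen and its place on the ring change, and nothing measured tells the outcome, so compound 4 is expected to stay near the limit region, with an at least 1.5-fold lower number from compound 3 to compound 4 (0.17 log units; that floor lies within the scatter) at most small. The estimate for compound 4 in this assay is 20000 nM, ranging from 5000 nM to 60000 nM.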

Compound 4, inhibition constant: > 30000 nM
Compound 4: a limit, no number; the forecaster's own chance of this, stated with the estimate: 50%; at least 1.5-fold (0.17 log units) between middle value and limit.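

In this assay, 2-chlorophenyl is a third replacement for the phenyl of compound 1 that ends at the limit of the assay, with an at least 3.5-fold higher number from compound 1 to compound 4 (0.54 log units; beyond the scatter). The steps among compound 2, compound 3 and compound 4 cannot be read, as both ends of each are limits, so 2-chlorophenyl cannot be ranked against 4-fluorophenyl or pyridin-3-yl. Compound 1 remains the only compound here with a number: the limit of > 30000 nM in this assay, at which 3 of the 4 values shown sit.

Going by these compounds, it remains open how far apart the three limited compounds lie. Also open, on these data alone, is whether a methoxy or an amine on the phenyl would keep or improve on compound 1 and its 8510 nM reading.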